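This account rests on a few compounds, and the source may have more. Where it says the series, first, only, none or still open, it means among the compounds named here.

Going by the values given here, compound 1 `Cc1ccc(NC(=O)[C@H]2CN(C)C[C@@H]2c2ccc(/C=C/C(=O)Nc3ccccc3N)cc2)cc1` carries the highest number among the three compounds measured so far: in an in vitro ADME assay on microsomes from liver (Homo sapiens) for pharmacokinetics, read by LC-MS, with a stated time of 10 min, tested at 1 uM (a higher number here means faster removal of the compound, a lower number slower removal), compound 1 gives 15 mL/min/kg. Compound 2 `CN1C[C@H](C(=O)Nc2cccc(Cl)c2)[C@@H](c2ccc(/C=C/C(=O)Nc3ccccc3N)cc2)C1` gives 7 mL/min/kg, and compound 3 `Cc1ccc(NC(=O)[C@H]2CN(C)C[C@@H]2c2ccc(/C=C/C(=O)Nc3ccccc3N)cc2)cn1` gives 8 mL/min/kg. The step of a 2.1-fold lower number from compound 1 to compound 2 (0.33 log units; beyond the scatter) lies beyond the scatter, whereas the step of a 1.9-fold lower number from compound 1 to compound 3 (0.27 log units; within the scatter) stays within it, and the step of a 1.1-fold higher number from compound 2 to compound 3 (0.06 log units; within the scatter) is also within the scatter. Compound 4 `CN1C[C@H](C(=O)Nc2ccccn2)[C@@H](c2ccc(/C=C/C(=O)Nc3ccccc3N)cc2)C1` differs from compound 1 in a single place: pyridin-2-yl in place of 4-methylphenyl on an amide-type nitrogen. Both measured replacements of the 4-methylphenyl group on the amide-type nitrogen led to lower numbers in this assay, and the one that brought in a 6-methylpyridin-3-yl group, compound 3, is the closer comparison because a 1.9-fold lower number from compound 1 to compound 3 (0.27 log units; within the scatter) was only a modest drop. Compound 4 is therefore expected to show at most a modest decrease, a 1.7-fold lower number from compound 1 to compound 4 (0.22 log units; within the scatter), quite possibly one that stays within the scatter. The estimate for compound 4 in this assay is 9 mL/min/kg, with a range from 5 mL/min/kg to 16 mL/min/kg.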

Compound 4, clearance: 8 mL/min/kg
For compound 4 the middle estimate is 1.1-fold (0.05 log units) above the measured one, and the stated range covers the measured number.
By their numbers in this assay, from the lowest: compounds 2, 3, 4 and 1 (each within the scatter of the next, the first and the last beyond it).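

With pyridin-2-yl on the amide-type nitrogen, this assay gives a 1.9-fold lower number from compound 1 to compound 4 (0.27 log units; within the scatter) and so does not separate this group from 4-methylphenyl. The two pyridine-bearing compounds also cannot be told apart, with no change at the digits printed from compound 3 to compound 4 (within the scatter) even though pyridin-2-yl carries no methyl group, and a ring without chlorine or methyl stays level with the 3-chlorophenyl group, with a 1.1-fold higher number from compound 2 to compound 4 (0.06 log units; within the scatter) as the step. Among these four compounds, this position therefore accepts a hetero atom in the aromatic ring with no step beyond the scatter, and only compound 2 remains beyond the scatter from compound 1.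

From the compounds shown here alone, how the read-out responds at this nitrogen to a cyclohexyl group, a longer alkyl chain or an aryl ring bearing a carboxylic acid or an amine remains open. No evidence is available to explain these numbers.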